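A Sulfur-Bearing Group Replaces Carbamoyl at the Assay Limit

A few compounds are considered here, and "the series" means these few. Any claim that something is new, unique, unknown or untested is made for them only; others in the source may bear on it.

In a functional assay on KB cells (Homo sapiens) for cytotoxicity (on this read-out higher numbers stand for weaker inhibition and lower numbers for stronger inhibition), compound 1 `COCCOCn1cc(C#N)c2c(N)ncnc21` gives > 100000 nM, which is a limit of the assay and not a number. Compound 2 `COCCOCn1cc(C(N)=O)c2c(N)ncnc21` gives > 100000 nM, which is also a limit. The change between them is a step that the two limits leave unreadable from compound 1 to compound 2. All that can be said of where compound 2 stands is the limit of > 100000 nM in this assay, at which 2 of the 2 values shown sit.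

Compound 3 `COCCOCn1cc(C(N)=S)c2c(N)ncnc21` differs from compound 2 by one change on an aromatic carbon: a group of 3 heavy atoms (1 carbon, 1 nitrogen, 1 sulfur; no ring) in place of a group of 3 heavy atoms (1 carbon, 1 nitrogen, 1 oxygen; no ring), on an aromatic carbon. Its new group holds sulfur where carbamoyl holds oxygen.

For the measured compounds named here, the one measured step has no readable size, so it offers no firm guide to the size or direction of this change. Only a modest move toward stronger inhibition is expected, an at least 1.4-fold lower number from compound 2 to compound 3 (0.15 log units; that floor lies within the scatter). Compound 3 is estimated at 70000 nM, with an expected range of 10000 nM to 200000 nM. Another limit in this assay is also quite possible.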

Compound 3, half-maximal inhibitory concentration: 183000 nM
Estimate against measurement, compound 3: 2.6-fold (0.42 log units) below; low and high end bracket the measured number.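

Compound 3 gives a real number, but the steps to it from compound 1 and compound 2 cannot be read, because both of those compounds stop at an assay limit: the limit of > 100000 nM in this assay, at which 2 of the 3 values shown sit.

On these data alone, how these three groups truly rank in this assay stays open.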